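Swapping 4-aminophenyl for chloro on the shared core

The compounds below may be only part of what the source reports. "The series", "measured", "known", "first", "only" and "open" are said of these compounds alone.

Measured so far in a functional assay on A549 cells (Homo sapiens) for inhibition, read by MTT assay, with a stated time of 72 h; on this read-out higher numbers stand for weaker inhibition and lower numbers for stronger inhibition:
- compound 1 `CC(C)(C)n1cc2c(n1)C(=O)CC1(CCN(C(=O)c3cc(-c4ccc(Cl)cc4)nc4ccccc34)CC1)O2` gives 2330 nM
- compound 2 `COc1ccc(-c2cc(C(=O)N3CCC4(CC3)CC(=O)c3nn(C(C)(C)C)cc3O4)c3ccccc3n2)cc1OC` gives 2030 nM
- compound 3 `CC(C)(C)n1cc2c(n1)C(=O)CC1(CCN(C(=O)c3cc(-c4ccc(N)cc4)nc4ccccc34)CC1)O2` gives 970 nM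

Compound 3 has the lowest number of the three, and its gaps to both others lie beyond the scatter. Compound 4 `CC(C)(C)n1cc2c(n1)C(=O)CC1(CCN(C(=O)c3cc(Cl)nc4ccccc34)CC1)O2` is still unmeasured. It differs from compound 3 in one place, with chloro in place of 4-aminophenyl (chloro in place of 4-aminophenyl on an aromatic carbon) on an aromatic carbon next to the ring nitrogen.

The measured steps all change the aryl group at this carbon. The step of a 1.1-fold lower number from compound 1 to compound 2 (0.06 log units; within the scatter) is small, while a 2.4-fold lower number from compound 1 to compound 3 (0.38 log units; beyond the scatter) and a 2.1-fold lower number from compound 2 to compound 3 (0.32 log units; beyond the scatter) are modest. All three compounds keep a phenyl ring there, so none shows what losing the ring does, and the estimate is uncertain. Compound 4 gives up the 4-aminophenyl of compound 3, which has the lowest value at 970 nM so far. A higher number is therefore expected, with an estimated 3.1-fold higher number from compound 3 to compound 4 (0.49 log units; beyond the scatter) as the likely size. In this assay compound 4 is expected at 3000 nM (estimated range 1100 nM to 8000 nM).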

Compound 4, half-maximal inhibitory concentration: 7170 nM
Compound 4: middle estimate off by 2.4-fold (0.38 log units), on the low side; measured number inside the range.
By their numbers in this assay, from the lowest: compound 3; then compounds 2 and 1 (each within the scatter of the next); then compound 4.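

In this assay taking the ring off this aromatic carbon raises the number whichever aryl group leaves: the steps are a 7.4-fold higher number from compound 3 to compound 4 (0.87 log units; beyond the scatter) and a 3.5-fold higher number from compound 2 to compound 4 (0.55 log units; beyond the scatter) and also a 3.1-fold higher number from compound 1 to compound 4 (0.49 log units; beyond the scatter), all beyond the scatter. Compound 4 is therefore the weakest of the four, and a phenyl ring on this carbon, whatever it carries in compounds 1, 2 and 3, goes with stronger inhibition than chloro alone. No measurement shown here explains why the ring matters.

On these data alone, it remains open whether another small group, such as a methyl or a plain amine, would behave like chloro here. It is also unknown whether an unsubstituted phenyl or a pyridyl ring would match the 4-aminophenyl of compound 3.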